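Swapping a Furan for a Methylphenyl on a Hydroxamate

The compounds below may be only part of what the source reports. "The series", "measured", "known", "first", "only" and "open" are said of these compounds alone.

Compound 1 `O=C(NO)c1ccc(NCc2nc(-c3ccco3)nn2-c2ccccc2)cc1` was tested in an assay on Sf9 cells for inhibition of protein deacetylase HDAC6 (Homo sapiens), read by fluorescence, with a stated time of 40 min, tested at 100 nM (on this read-out lower numbers stand for less inhibition and higher numbers for more inhibition at the one concentration tested (going by the name of the read-out)), and gives 59.9% there. Within the data shown here, of the two compounds measured so far, compound 1 stands lowest; its only neighbour, compound 2 `COc1ccc(-n2nc(-c3ccc(O)cc3)nc2CNc2ccc(C(=O)NO)cc2)cc1`, gives 70.3% in this assay, a number that lies beyond the usual scatter above compound 1. Among the measured compounds shown here, no pair of measured compounds that differ in a single place is available, so nothing is yet known about how a single change moves the read-out.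

Compound 3 `Cc1ccccc1-c1nc(CNc2ccc(C(=O)NO)cc2)n(-c2ccccc2)n1` has not been measured. It differs from compound 1 in one place: 2-methylphenyl in place of furan-2-yl on an aromatic carbon. The rest of the shared core of compound 1 is kept unchanged. For the measured compounds named here, with no comparable measured step to lean on, the step from compound 1 to compound 3 in this assay is expected to be small and of no sure direction, a number 1.9 percentage points lower from compound 1 to compound 3 (within the scatter), not clearly beyond the scatter. Compound 3 is therefore estimated to give 58%, within a range from 40% to 75%.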

Compound 3, a percentage reported as inhibition, at one concentration (the size of the read-out at that concentration, not a potency): 53.2%
The estimate for compound 3 lay 4.8 percentage points above the measured number, and the stated range covers the measured number.
By their numbers in this assay, from the lowest: compounds 3 and 1 (each within the scatter of the next); then compound 2.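

In this assay the series now has its first step at a single place, a number 6.7 percentage points lower from compound 1 to compound 3 (within the scatter), with 2-methylphenyl in place of furan-2-yl on an aromatic carbon of a five-membered aromatic ring with 3 nitrogen, between two ring nitrogen atoms. This position therefore accepts a six-movement from one ring type to another without a step beyond the scatter: the five-membered aromatic ring with its single hydrogen-bond acceptor and 5 heavy atoms gives way to a six-membered aromatic ring of carbon only with 7 heavy atoms, and the two compounds stay within the scatter of each other. No measurement at hand explains why this exchange leaves the two numbers so close.

The compounds shown cover only these two aromatic rings at this position, so it remains open whether a group of another kind there, such as a carboxylic acid or an aminomethyl chain, would give a step beyond the scatter. Also open, from the compounds shown here alone, is whether the same exchange would read alike on a core carrying other groups, and at concentrations other than the single one tested.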